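The compounds below may be only part of what the source reports. "The series", "measured", "known", "first", "only" and "open" are said of these compounds alone.

Measured compounds:
Compound 1 `C=CC(=O)Nc1cc2c(Nc3ccc(OCc4cccc(F)c4)c(Cl)c3)ncnc2cc1OCc1cn(CCCC(=O)NO)nn1` — in an ADME assay on FHC cells (Homo sapiens) for cytotoxicity, read by MTT assay, with a stated time of 72 h (on this read-out higher numbers stand for weaker inhibition and lower numbers for stronger inhibition), compound 1 gives > 25000 nM, which is a limit of the assay.
Compound 2 `C=CC(=O)Nc1cc2c(Nc3ccc(OCc4cccc(F)c4)c(Cl)c3)ncnc2cc1OCc1cn(CCCCC(=O)NO)nn1` — in this assay compound 2 gives > 25000 nM, also a limit.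
Compound 3 `C=CC(=O)Nc1cc2c(Nc3ccc(F)c(Cl)c3)ncnc2cc1OCc1cn(CCCC(=O)NO)nn1` — in this assay compound 3 gives > 25000 nM, again a limit.

Compound 1 thus stands only at a limit in this assay, and so do the other two, as the limit of > 25000 nM in this assay, at which 3 of the 3 values shown sit, records. Compound 4 `C=CC(=O)Nc1cc2c(Nc3ccc(OCc4cccc(F)c4)c(Cl)c3)ncnc2cc1OCc1cn(CCC(=O)NO)nn1` differs from compound 1 by hydroxycarbamoyl in place of (hydroxycarbamoyl)methyl on a saturated chain carbon, two bonds along the chain from an aromatic nitrogen. The nearest measured steps are a step that the two limits leave unreadable from compound 1 to compound 2 and a step that the two limits leave unreadable from compound 1 to compound 3; neither can be read in size because of the limit of > 25000 nM in this assay, at which 3 of the 3 values shown sit. A readable step in this assay is therefore not expected in either direction. Compound 4 is estimated at 40000 nM, within 15000 nM to 120000 nM, most likely reported again as a limit, so that the step that the limit leaves unreadable from compound 1 to compound 4 is expected to stay unreadable.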

Compound 4, half-maximal inhibitory concentration: > 25000 nM
Compound 4: a limit, no number (the forecaster's own chance of this, stated with the estimate: 85%); the middle value lies beyond the limit too.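

No step from compound 1 or compound 2 to compound 4 can be read in size, because all the values stand at a limit: the limit of > 25000 nM in this assay, at which 4 of the 4 values shown sit.

The compounds shown leave open whether chain length, or fluoro in place of (3-fluorobenzyl)oxy, changes the result in this assay at all.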